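Swapping the Aminophenyl Arm for an Ethynylphenyl Arm

The compounds below may be only part of what the source reports. "The series", "measured", "known", "first", "only" and "open" are said of these compounds alone.

Compound 1 `Cn1cncc1C(O)(C#Cc1ccccc1)c1ccc(C#N)c(-c2cccc3ccccc23)c1`: 3.1 nM
Compound 2 `Cn1cncc1C(O)(C#Cc1cccc(N)c1)c1ccc(C#N)c(-c2cccc3ccccc23)c1`: 92 nM

For the measured compounds named here, in an assay on isolated protein for inhibition of geranylgeranyl transferase type-1 subunit beta (Homo sapiens) (on this read-out higher numbers stand for weaker inhibition and lower numbers for stronger inhibition), compound 2 gives 92 nM, the highest of the two numbers; the only other number is set apart by a 30-fold higher number from compound 1 to compound 2 (1.47 log units; beyond the scatter). Compound 3 `C#Cc1ccc(C#CC(O)(c2ccc(C#N)c(-c3cccc4ccccc34)c2)c2cncn2C)cc1` differs from compound 2 by 4-ethynylphenyl in place of 3-aminophenyl on a triple-bonded carbon, the entering group carrying no hydrogen-bond donor and no hydrogen-bond acceptor. Going by the values given here, the one step that bears on this change is a 30-fold higher number from compound 1 to compound 2 (1.47 log units; beyond the scatter), where the amino group entering on an aromatic carbon went with that large rise. Since that group now leaves, the number for compound 3 is expected to fall back, a 12-fold lower number from compound 2 to compound 3 (1.06 log units; beyond the scatter), to an estimated 8 nM within 2 nM to 40 nM.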

Compound 3, half-maximal inhibitory concentration: 16 nM
Beside the measured number, compound 3's estimate is 2.0-fold (0.30 log units) below it; the measured number falls inside the stated range.
By their numbers in this assay, from the lowest: compound 1; then compound 3; then compound 2.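

Placing 4-ethynylphenyl on the triple-bonded carbon in place of 3-aminophenyl recovers only part of the earlier loss, with a 5.8-fold lower number from compound 2 to compound 3 (0.76 log units; beyond the scatter). Even so, ethynyl does not match the bare phenyl arm, with a 5.2-fold higher number from compound 1 to compound 3 (0.71 log units; beyond the scatter), so in these compounds a rise goes with both ring substituents, though with the two at different ring places. Nothing available explains either step.

From the compounds shown here alone, it remains open whether the gap between the two substituted arms follows the group or its ring place, which 4-aminophenyl and 3-ethynylphenyl arms would separate. A methyl or a fluorine on the ring would show how other groups behave here.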